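The source may report more compounds than this note shows. Statements on the series, on what has been measured and on what is new or still open speak of the compounds shown alone.

Measured in an ADME assay (liver) for metabolic stability, with Liver microsome (Homo sapiens) as the target, using microsomes and NADPH, with a stated time of 30 min, tested at 1 uM; on this read-out lower numbers stand for slow clearance and higher numbers for fast clearance:

Compound 1 `CC(C)(O)C#Cc1cc(C(O)(C(F)(F)F)C(F)(F)F)cnc1N1CCN(S(=O)(=O)c2ccc(N)nc2)CC1`: < 14 mL.min-1.g-1 (a limit)
Compound 2 `Cc1nc2cc(-c3cc(C(O)(C(F)(F)F)C(F)(F)F)cnc3N3CCN(S(=O)(=O)c4ccc(N)nc4)CC3)ccc2o1`: < 14 mL.min-1.g-1 (a limit)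

Compound 2 gives no number in this assay and stands at the limit of < 14 mL.min-1.g-1 in this assay, at which 2 of the 2 values shown sit. The unmeasured compound 3 `Nc1ccc(S(=O)(=O)N2CCN(c3ncc(C(O)(C(F)(F)F)C(F)(F)F)cc3-c3ccc4c(c3)CC(=O)N4)CC2)cn1` has the same atoms as compound 2, joined differently: a group of 10 heavy atoms (8 carbon, 1 nitrogen, 1 oxygen; one five-membered non-aromatic ring with 1 hetero atom, one six-membered aromatic ring of carbon only) in place of a group of 10 heavy atoms (8 carbon, 1 nitrogen, 1 oxygen; one five-membered aromatic ring with 2 hetero atoms, one six-membered aromatic ring of carbon only), on an aromatic carbon. A five-membered non-aromatic ring with 1 hetero atom thus replaces a five-membered aromatic ring with 2 hetero atoms.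

Among the compounds with values here, only one measured step bears on this: a step that the two limits leave unreadable from compound 1 to compound 2. It puts 2-methyl-1,3-benzoxazol-5-yl in place of 3-hydroxy-3-methylbut-1-yn-1-yl on an aromatic carbon, and it offers no size to carry over. No step beyond the usual scatter is expected in this assay, and no direction can be given. The expected change is a step that the limit leaves unreadable from compound 2 to compound 3. The estimate for compound 3 is 12 mL.min-1.g-1, with an expected range of 5 mL.min-1.g-1 to 25 mL.min-1.g-1.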

Compound 3, intrinsic clearance in microsomes: < 14 mL.min-1.g-1
Compound 3: a limit, no number (the forecaster's own chance of this, stated with the estimate: 70%); the middle value is on the limit's open side.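

Compound 3 gives only a limit in this assay, as do compound 1 and compound 2, so no step among the three can be read: the limit of < 14 mL.min-1.g-1 in this assay, at which 3 of the 3 values shown sit.

The compounds shown leave open whether compound 1, compound 2 and compound 3 truly differ in this assay, and by how much.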